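The compounds below may be only part of what the source reports. "The series", "measured", "known", "first", "only" and "open" are said of these compounds alone.

Compound 1 `CC(=O)Nc1c(C(O)(C(F)(F)F)C(F)(F)F)ccc2ccccc12` gives 18 nM in an assay on LtK cells with ATP-sensitive inward rectifier potassium channel 11 (Homo sapiens) as the target; a lower number here means that less compound is needed, a higher number that more compound is needed for the effect. Within the data shown here, compound 2 `O=C(Nc1c(C(O)(C(F)(F)F)C(F)(F)F)ccc2ccccc12)c1ccc(Cl)cc1` gives 570 nM in this assay, the highest of the two numbers known so far; its only neighbour is compound 1, and the step between them is a 32-fold higher number from compound 1 to compound 2 (1.50 log units; beyond the scatter). Compound 3 `O=C(Nc1c(C(O)(C(F)(F)F)C(F)(F)F)ccc2ccccc12)c1ccc(OC(F)(F)F)cc1` has not been measured. It differs from compound 2 in a single place: trifluoromethoxy in place of chloro on an aromatic carbon. Among the measured compounds shown here, no measured step bears directly on this exchange; the one step that exists, from compound 1 to compound 2, concerns the group on the carbonyl carbon rather than a substituent of the 4-chlorophenyl ring, and it shows only that this part of the molecule can move the number a great deal. Lacking a guide of its own, compound 3 is expected to stay close to compound 2, with an expected step of a 1.2-fold higher number from compound 2 to compound 3 (0.09 log units; within the scatter) in this assay, not beyond the scatter. The estimate for compound 3 is 700 nM, within 200 nM to 2500 nM.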

Compound 3, half-maximal effective concentration: > 10000 nM
Compound 3 was reported as a limit (the forecaster's own chance of this, stated with the estimate: 5%); at least 14-fold (1.15 log units) between middle value and limit.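

Compound 3 is reported only as a limit, not as a number, in this assay: the limit of > 10000 nM in this assay, at which 1 of the 3 values shown sits. The earlier compounds shown here showed that replacing the methyl on the carbonyl carbon can move the number a great deal; this result shows that a change confined to the substituent on the aromatic ring, 4-chlorophenyl to 4-(trifluoromethoxy)phenyl, can also do so, with an at least 17-fold higher number from compound 2 to compound 3 (1.24 log units; beyond the scatter). Measured against the methyl group, the 4-(trifluoromethoxy)phenyl group gives an at least 550-fold higher number from compound 1 to compound 3 (2.74 log units; beyond the scatter).

The compounds shown cannot tell how far beyond the limit compound 3 lies, or whether the oxygen or the fluorines of the trifluoromethoxy group account for the step. They also leave open how a methoxy group or an amine would read in place of chloro on this aromatic carbon.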